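The compounds below may be only part of what the source reports. "The series", "measured", "known", "first", "only" and "open" are said of these compounds alone.

Among the compounds with values here, compound 2, `N[C@@H]1CS[C@@H](n2cnc3c(NCc4cccc(I)c4)ncnc32)[C@@H]1O`, is the higher of the two numbers so far in an assay on membranes from CHO cells for displacement of a labelled ligand from adenosine receptor A1 (Homo sapiens), read by scintillation counting, with a stated time of 60 min; on this read-out higher numbers stand for weaker inhibition and lower numbers for stronger inhibition: compound 2 gives 2450 nM, and its nearest neighbour, compound 1, `N[C@@H]1CS[C@@H](n2cnc3c(NCc4cccc(I)c4)nc(Cl)nc32)[C@@H]1O`, gives 2200 nM, the two lying within the scatter, as a 1.1-fold higher number from compound 1 to compound 2 (0.05 log units; within the scatter) shows. Compound 3, `CNc1ncnc2c1ncn2[C@@H]1SC[C@@H](N)[C@H]1O`, has not been measured; it differs from compound 2 by hydrogen in place of 3-iodophenyl on a saturated chain carbon bound to a nitrogen on an aromatic ring, the same difference, cut one bond further out, reading 3-iodobenzyl to methyl. Within the data shown here, the only measured step concerns chloro against hydrogen on an aromatic carbon and does not bear on this change. Compound 3 is therefore expected to give 6000 nM, between 1500 nM and 25000 nM, a step of a 2.4-fold higher number from compound 2 to compound 3 (0.39 log units; beyond the scatter) that is only an estimate.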

Compound 3, inhibition constant: 1670 nM
Compound 3: the middle estimate sits 3.6-fold (0.56 log units) above what was measured; the range from low to high includes it.
By their numbers in this assay, from the lowest: compounds 3, 1 and 2 (each within the scatter of the next).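

In this assay, the change from 3-iodobenzyl to methyl stays within the scatter (a 1.5-fold lower number from compound 2 to compound 3 (0.17 log units; within the scatter)). The earlier compounds shown here varied only chloro against hydrogen on an aromatic carbon, whereas this pair shows that at this position the 3-iodophenyl group, with its seven heavy atoms, can go without a change beyond the scatter. Nothing available explains this result.
On these data alone, it remains open whether an unsubstituted benzyl, a longer chain such as n-butyl, or a carboxylic acid on that chain would also stay within the scatter. As far as these compounds go, whether chloro against hydrogen reads the same alongside methyl also remains open.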